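The source may hold more compounds than are shown below. What is called first, only, known or untested is meant among the compounds shown, and "the series" means these compounds.

In a functional assay on HCT-116 cells (Homo sapiens) for antiproliferative activity, read by sulforhodamine B assay, with a stated time of 72 h (on this read-out lower numbers stand for stronger inhibition and higher numbers for weaker inhibition), compound 1 `Cn1cc(-c2ccc(=O)n(CCOc3ccnc4cc(OCCCC(=O)NO)ccc34)n2)cn1` gives > 10000 nM, which is a limit of the assay and not a number. Compound 1 therefore has no exact place on the scale. Two relatives do give numbers: compound 2 `Cn1cc(-c2ccc(=O)n(CCOc3ccnc4cc(OCc5ccc(/C=C/C(=O)Nc6ccccc6N)nc5)ccc34)n2)cn1` reads 7900 nM, and compound 3 `Cn1cc(-c2ccc(=O)n(CCOc3ccnc4cc(OCCCOc5ccc(C(=O)Nc6ccccc6N)nc5)ccc34)n2)cn1` reads 1300 nM.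

Compound 4 `Cn1cc(-c2ccc(=O)n(CCOc3ccnc4cc(C(=O)Nc5ccccc5N)ccc34)n2)cn1` has not yet been measured in this assay. It differs from compound 1 at one place: (2-aminophenyl)carbamoyl in place of 3-(hydroxycarbamoyl)propoxy on an aromatic carbon. In words, (2-aminophenyl)carbamoyl stands in place of 3-(hydroxycarbamoyl)propoxy on an aromatic carbon.

The entering group also occurs in compound 2, at 7900 nM, and in compound 3, at 1300 nM, so an exact number seems likely for compound 4 as well. However, in neither relative is it attached directly to the shared core, so these values offer only a rough guide. The expected at least 1.6-fold lower number from compound 1 to compound 4 (0.22 log units; that floor lies within the scatter) is a modest one towards stronger inhibition, and its true size remains uncertain without an exact starting number. For compound 4, the estimated value is 6000 nM, with an expected range from 1500 nM to 20000 nM.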

Compound 4, half-maximal inhibitory concentration: > 10000 nM
Compound 4 ended at the assay's limit; the forecaster's own chance of this, stated with the estimate: 40%; middle value at least 1.6-fold (0.22 log units) away from the limit.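

In this assay compound 1 and compound 4 both end at a limit and not at a number, so no step between them can be read: the limit of > 10000 nM in this assay, at which 2 of the 4 values shown sit.

The compounds shown leave open whether (2-aminophenyl)carbamoyl in place of 3-(hydroxycarbamoyl)propoxy changes the antiproliferative activity at all.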